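Carbamate in Place of Methyl on the Piperazine Nitrogen

A few compounds are considered here, and "the series" means these few. Any claim that something is new, unique, unknown or untested is made for them only; others in the source may bear on it.

Measured compounds:
- compound 1, `c1nnc2nnc(N3CCCC3)nn12`: 24400 nM
- compound 2, `CN1CCN(c2nnc3nncn3n2)CC1`: 8540 nM

In a functional assay on HL-60 cells (Homo sapiens) for inhibition, read by MTT assay, with a stated time of 72 h (on this read-out higher numbers stand for weaker inhibition and lower numbers for stronger inhibition), compound 2 gives the lower of the two numbers; compound 1 gives the higher one, and the gap between them lies beyond the scatter. Compound 3, `CC(C)COC(=O)N1CCN(c2nnc3nncn3n2)CC1`, has not been measured. It differs from compound 2 by isobutoxycarbonyl in place of methyl on an amine nitrogen in a ring. Within the data shown here, no step of that kind has been measured here, so the expectation rests on compound 2 alone: the step from compound 2 to compound 3 is expected to be small, a 1.4-fold higher number from compound 2 to compound 3 (0.15 log units; within the scatter), leaning toward a higher number. Compound 3 is estimated at 12000 nM, within 3000 nM to 50000 nM.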

Compound 3, half-maximal inhibitory concentration: 7930 nM
Compound 3: middle estimate off by 1.5-fold (0.18 log units), on the high side; the range from low to high includes it.
By their numbers in this assay, from the lowest: compounds 3 and 2 (each within the scatter of the next); then compound 1.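

In this assay, isobutoxycarbonyl in place of methyl on this amine nitrogen in a ring gives a step that stays within the scatter (a 1.1-fold lower number from compound 2 to compound 3 (0.03 log units; within the scatter)). The position thus carries a group of seven heavy atoms, with two hydrogen-bond acceptors and a carbonyl, and the read-out does not separate it from methyl. No measurement shown here accounts for this result. Going by these compounds, whether a free amine hydrogen, an acetyl group or a longer alkyl chain on this nitrogen would read the same remains open. So does whether a urea would match the carbamate of compound 3.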